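Shrinking the amine substituent of compound 1

This account rests on a few compounds, and the source may have more. Where it says the series, first, only, none or still open, it means among the compounds named here.

Among the measured compounds shown here, compound 1 (`CCOC(=O)C1=C(N/N=C(/C(=O)Br)c2ccc(Br)cc2)Nc2[nH]nc(C)c2C1c1ccc(N(C)C)cc1`) gives 61300 nM in a functional assay on MCF7 cells (Homo sapiens) for inhibition, read by MTT assay, with a stated time of 48 h (on this read-out higher numbers stand for weaker inhibition and lower numbers for stronger inhibition), and holds the higher of the two numbers so far, with compound 2 (`CCOC(=O)C1=C(N/C=N/c2ncc(-c3ccccc3)s2)Nc2[nH]nc(C)c2C1c1ccc(N(C)C)cc1`) at 10100 nM on the shared core. Compound 3 (`CCOC(=O)C1=C(N/N=C(/Cl)C#N)Nc2[nH]nc(C)c2C1c1ccc(N(C)C)cc1`) keeps that core and carries one change (a group of 5 heavy atoms (2 carbon, 2 nitrogen, 1 chlorine; no ring) in place of a group of 12 heavy atoms (8 carbon, 1 nitrogen, 1 oxygen, 2 bromine; one six-membered aromatic ring of carbon only), on an amine nitrogen). For the measured compounds named here, no measured pair isolates this change, and the only guide is compound 2 (10100 nM), which has a different group on that nitrogen. The expected move in this assay is downward and beyond the scatter (a 3.1-fold lower number from compound 1 to compound 3 (0.49 log units; beyond the scatter)), though its size remains uncertain. For compound 3 the estimated value is 20000 nM (range 6000 nM to 60000 nM).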

Compound 3, half-maximal inhibitory concentration: 23200 nM
Compound 3: the middle estimate sits 1.2-fold (0.06 log units) below what was measured; measured number inside the range.
By their numbers in this assay, from the lowest: compound 2; then compound 3; then compound 1.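

On the amine nitrogen of the shared core, in this assay, the smaller group without a ring gives a 2.6-fold lower number from compound 1 to compound 3 (0.42 log units; beyond the scatter), so the six-membered aromatic ring of carbon only and the two bromines are not required for a lower number at this position. Compound 2, whose group on that nitrogen holds rings, still gives the lowest number at 10100 nM. Nothing at hand explains the step.

Still open, from the compounds shown here alone, is whether the chlorine or the nitrile carries the step. A carboxylic acid or a short alkyl chain on that nitrogen would help separate group size from group identity.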